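The source may hold more compounds than are shown below. What is called first, only, known or untested is meant among the compounds shown, and "the series" means these compounds.

In an assay on HEK293 cells for binding affinity to 5-hydroxytryptamine receptor 7 (Homo sapiens), read by radioligand binding, tested at 1 uM (a higher number here means more inhibition at the concentration tested (going by the name of the read-out), a lower number less inhibition), compound 1, with the structure `CCc1ccc2ccn(CCN3CCCN(C)CC3)c2c1`, gives 66%, and compound 2, with the structure `CC(C)c1ccc2ccn(CCN3CCCN(C)CC3)c2c1`, gives 72%. The change between them is methyl in place of hydrogen on a saturated chain carbon bound to an aromatic carbon and a saturated chain carbon, and it makes a number 6 percentage points higher from compound 1 to compound 2 (within the scatter). Compound 3, with the structure `CC(C)CN1CCCN(CCn2ccc3ccc(Br)cc32)CC1`, gives 95% in this assay; how its core differs from that of compound 1 is not broken down here. Compound 4, with the structure `CC(C)(C)CN1CCCN(CCn2ccc3ccc(Br)cc32)CC1`, differs from compound 3 by methyl in place of hydrogen on a saturated chain carbon bound to three saturated chain carbons. This is the same kind of change as from compound 1 to compound 2, but at a different place: there the carbon was bound to an aromatic carbon and a saturated chain carbon, here it is bound to three saturated chain carbons. Resting on compound 3 at 95% and the small step of a number 6 percentage points higher from compound 1 to compound 2 (within the scatter), the expected step is a number 7 percentage points lower from compound 3 to compound 4 (within the scatter). Compound 4 is estimated at 88% in this assay.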

Compound 4, a percentage reported as inhibition, at one concentration (the size of the read-out at that concentration, not a potency): 70%
Compound 4: the middle estimate sits 18 percentage points above what was measured; low and high end bracket the measured number.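

In this assay, putting a methyl in place of a hydrogen, which turns isobutyl into neopentyl, gives a number 25 percentage points lower from compound 3 to compound 4 (beyond the scatter). The same change therefore does not carry over as a fixed step from one core to the other: the same change on two cores in this assay, a number 6 percentage points higher (within the scatter) from compound 1 to compound 2 and a number 25 percentage points lower (beyond the scatter) from compound 3 to compound 4, 31 percentage points apart, beyond the scatter of two such steps. The two pairs differ both in the core and in the kind of carbon that takes the methyl, and with one pair for each, they cannot show which of these sets the gap, nor do they give a rule for the whole series.

The compounds shown leave open how the core of compound 3 would respond to a longer chain, such as n-hexyl, in place of neopentyl. They also leave open how it would respond to an amine at the end of that chain.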